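The source may report more compounds than this note shows. Statements on the series, on what has been measured and on what is new or still open speak of the compounds shown alone.

Series notes. For the measured compounds named here, compound 1 `Cc1cc(C)c(NC(=O)c2sccc2S(=O)(=O)Nc2onc(C)c2Cl)c(Cl)c1` is the reference point; in an ADME assay on the whole organism for pharmacokinetics, with Rattus norvegicus as the target (on this read-out higher numbers stand for a longer-lived compound and lower numbers for a shorter-lived compound), compound 1 gives 2.6 h, which is the lower of the two numbers so far, though only by a gap inside the scatter. Compound 2 `C/C(=N\O)c1cc(C)cc(C)c1NC(=O)c1sccc1S(=O)(=O)Nc1onc(C)c1Cl` is the sole comparator: in this assay compound 2 gives 5.2 h, and the step of a 2.0-fold higher number from compound 1 to compound 2 (0.30 log units; within the scatter) is within the scatter, so the two values cannot be ordered.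

Compound 3 `CO/N=C(\C)c1cc(C)cc(C)c1NC(=O)c1sccc1S(=O)(=O)Nc1onc(C)c1Cl` is not yet measured. Its change from compound 1 is a group of 5 heavy atoms (3 carbon, 1 nitrogen, 1 oxygen; no ring) in place of one chlorine atom, on an aromatic carbon. Going by the values given here, the one measured step that bears on it is a 2.0-fold higher number from compound 1 to compound 2 (0.30 log units; within the scatter), which put a group of 4 heavy atoms (2 carbon, 1 nitrogen, 1 oxygen; no ring) in place of one chlorine atom, on an aromatic carbon, and stayed within the scatter. Among the compounds with values here, no measured step separates the group entering in compound 3 from the group present in compound 2. The expectation for compound 3 in this assay is therefore a step of the size a 1.7-fold higher number from compound 1 to compound 3 (0.24 log units; within the scatter), not expected to go beyond the scatter. Compound 3 is estimated at 4.5 h, with a range from 2.2 h to 9.5 h.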

Compound 3, half-life: 1.2 h
The estimate for compound 3 lay 3.8-fold (0.57 log units) above the measured number, outside the stated range (below it).
By their numbers in this assay, from the lowest: compound 3; then compounds 1 and 2 (each within the scatter of the next).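

In this assay, for the compounds shown here, this aromatic carbon does not treat closely related groups alike: putting the group of compound 3 in place of chloro gives a 2.2-fold lower number from compound 1 to compound 3 (0.34 log units; beyond the scatter), the first step at this position to pass the scatter. Going by these compounds alone, the sharper result is the single change of methyl in place of hydrogen on an oxygen, which gives a 4.3-fold lower number from compound 2 to compound 3 (0.64 log units; beyond the scatter), so the outcome at this position turns on that one small difference within the entering group and not only on chloro leaving. Nothing available here offers an explanation for this drop in half-life.

From the compounds shown here alone, it remains open whether the lower number belongs to methyl alone or carries over to an ethyl group or a longer chain on the same oxygen. Going by these compounds, it is also open whether a smaller replacement for chloro on this aromatic carbon, such as a nitrile or a methoxy group, would fall with compounds 1 and 2 or with compound 3.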